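A few compounds are considered here, and "the series" means these few. Any claim that something is new, unique, unknown or untested is made for them only; others in the source may bear on it.

In a functional assay on MCF7 cells (Homo sapiens) for antiproliferative activity, read by MTT assay, with a stated time of 72 h (a higher number here means a weaker inhibitor, a lower number a stronger inhibitor), compound 1 `CC(C)c1ccc(NCC(=O)N[C@H]2CCOC2=O)cc1` gives > 64000 nM as a limit of the assay, not a number. Compound 2 `Cc1cc(Cl)ccc1NCC(=O)N[C@H]1CCOC1=O` gives > 64000 nM as a limit too. Compound 1 stands at the limit of > 64000 nM in this assay, at which 2 of the 2 values shown sit, and has no exact number. Compound 3 `O=C(CNc1ccc(Br)cc1)N[C@H]1CCOC1=O` carries bromo in place of isopropyl on an aromatic carbon, the counted change being bromo in place of isopropyl on an aromatic carbon in that one place. Within the data shown here, no measured pair shows this change, so the expected size is a number no higher from compound 1 to compound 3 (the limit leaves the size open) and no shift beyond the scatter is expected in this assay in either direction. The estimate for compound 3 is 64000 nM within a range from 30000 nM to 128000 nM and it is expected that the result may well be only a limit.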

Compound 3, half-maximal inhibitory concentration: > 64000 nM
Compound 3 was reported as a limit (the forecaster's own chance of this, stated with the estimate: 85%); the middle value lies on the limit itself.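

No step from compound 1 to compound 3 can be read, because both compounds sit at a limit of the assay, not at a number: the limit of > 64000 nM in this assay, at which 3 of the 3 values shown sit.

The compounds shown leave open whether bromo and isopropyl differ at all in their effect on these cells.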